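The source may hold more compounds than are shown below. What is called first, only, known or untested is meant among the compounds shown, and "the series" means these compounds.

Working notes on the series. Compound 1 `COc1cc(C(=O)c2sc(-c3cccs3)cc2N)cc(OC)c1OC` bears a thiophen-2-yl group on the shared core; in a functional assay on CCRF-CEM cells (Homo sapiens) for antiproliferative activity (on this read-out higher numbers stand for weaker inhibition and lower numbers for stronger inhibition), compound 1 gives 9.4 nM. Compound 2 `COc1cc(C(=O)c2sc(-c3ccc(Cl)cc3)cc2N)cc(OC)c1OC` carries 4-chlorophenyl in the same place, and in this assay compound 2 gives 70 nM. Compound 3 `CCOc1ccc(-c2cc(N)c(C(=O)c3cc(OC)c(OC)c(OC)c3)s2)cc1` carries 4-ethoxyphenyl there; in this assay compound 3 gives 270 nM, the highest of the three numbers. The steps from compound 1 are a 7.4-fold higher number from compound 1 to compound 2 (0.87 log units; beyond the scatter) and a 29-fold higher number from compound 1 to compound 3 (1.46 log units; beyond the scatter); between the two phenyl compounds the step is a 3.9-fold higher number from compound 2 to compound 3 (0.59 log units; beyond the scatter), so the substituent on the phenyl ring alone has moved the number beyond the scatter.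

Compound 4 `COc1cc(C(=O)c2sc(-c3cccc([N+](=O)[O-])c3)cc2N)cc(OC)c1OC` is not yet measured. Its change from compound 3 is 3-nitrophenyl in place of 4-ethoxyphenyl on an aromatic carbon. Among the measured compounds shown here, no measured step exchanges a nitro group, so the only bearing comes from the phenyl substituent step a 3.9-fold higher number from compound 2 to compound 3 (0.59 log units; beyond the scatter) and from the wider spread of aryl groups seen in a 29-fold higher number from compound 1 to compound 3 (1.46 log units; beyond the scatter). Compound 4 keeps a six-membered aromatic ring of carbon only, as in compound 2 and compound 3, so its number is expected to fall between those two rather than reach compound 1. For the measured compounds named here, the step expected is a 3.4-fold lower number from compound 3 to compound 4 (0.53 log units; beyond the scatter), a lower number in this assay, though with wide uncertainty because a 3.9-fold higher number from compound 2 to compound 3 (0.59 log units; beyond the scatter) is the only direct guide. For compound 4 the estimate in this assay is 80 nM, within 20 nM to 350 nM.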

Compound 4, half-maximal inhibitory concentration: 5.9 nM
The estimate for compound 4 lay 14-fold (1.13 log units) above the measured number; the whole stated range lies above it.
By their numbers in this assay, from the lowest: compounds 4 and 1 (each within the scatter of the next); then compound 2; then compound 3.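

Working notes on the series, position on an aromatic carbon next to the ring sulfur. In this assay, a six-membered aromatic ring of carbon only is compatible with a low number at this place, so the high numbers of the two earlier phenyl compounds do not extend to every phenyl group: 3-nitrophenyl in place of 4-ethoxyphenyl gives a large step (a 46-fold lower number from compound 3 to compound 4 (1.66 log units; beyond the scatter)), and 3-nitrophenyl in place of 4-chlorophenyl also gives a large step (a 12-fold lower number from compound 2 to compound 4 (1.07 log units; beyond the scatter)). The earlier compounds shown here set thiophen-2-yl apart from both phenyl groups, but compound 4 goes against that pattern, since the exchange of thiophen-2-yl for 3-nitrophenyl stays within the scatter (a 1.6-fold lower number from compound 1 to compound 4 (0.20 log units; within the scatter)) and leaves the two groups without an order in this assay. Nothing among the data given accounts for these steps.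

The compounds shown do not separate the nitro group from its place on the phenyl ring, since compound 4 differs from compound 2 and compound 3 in both. As far as these compounds go, whether a nitrile, an amine or a carboxylic acid on the phenyl ring would give a number close to that of compound 4 also stays open.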